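This account rests on a few compounds, and the source may have more. Where it says the series, first, only, none or still open, it means among the compounds named here.

Working notes on the series. In a functional assay on MCF7 cells (Homo sapiens) for inhibition, read by MTT assay, with a stated time of 48 h, tested at 10 uM (on this read-out higher numbers stand for more inhibition of growth at the one concentration tested and lower numbers for less inhibition of growth), compound 1 (`Cc1cc(=O)c2c(O)cc(OC/C=C/c3ccccc3)c([C@H]3CCN(C)C[C@H]3O)c2o1`) gives 7%, and compound 2 (`Cc1cc(=O)c2c(O)cc(OCc3ccco3)c([C@H]3CCN(C)C[C@H]3O)c2o1`) gives 6%. Compound 3 (`CCN(CC)Cc1c(O)c([C@H]2CCN(C)C[C@H]2O)c2oc(C)cc(=O)c2c1O`) gives 24%, the highest of the three numbers, and its gaps to compound 1 and compound 2 both lie beyond the scatter.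

The next compound to read is compound 4 (`CCOC(=O)N1CCN(Cc2c(O)c([C@H]3CCN(C)C[C@H]3O)c3oc(C)cc(=O)c3c2O)CC1`). It differs from compound 3 in one group: 4-(ethoxycarbonyl)piperazin-1-yl in place of diethylamino on a saturated chain carbon bound to an aromatic carbon. This puts 4-(ethoxycarbonyl)piperazin-1-yl in place of diethylamino on a saturated chain carbon bound to an aromatic carbon.

Within the data shown here, the only measured step, a number 1 percentage points lower from compound 1 to compound 2 (within the scatter), lies within the scatter. It sits elsewhere, on a saturated chain carbon bound to an oxygen on an aromatic ring, so it bears only weakly on this change. Among the measured compounds shown here, no measured step covers the place that changes here. Compound 3 differs from compound 1 and compound 2 in more than one place, so its higher number cannot be tied to the diethylamino group alone.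

A small downward move in this assay is expected, not beyond the scatter, with the estimated step being a number 6 percentage points lower from compound 3 to compound 4 (within the scatter). The estimate for compound 4 is 18%, with an expected range of 5% to 34%.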

Compound 4, percent growth inhibition at one concentration: 31%
Compound 4: middle estimate off by 13 percentage points, on the low side; low and high end bracket the measured number.
By their numbers in this assay, from the lowest: compounds 2 and 1 (each within the scatter of the next); then compounds 3 and 4 (each within the scatter of the next).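

In this assay, among these compounds, the step at this place, a number 7 percentage points higher from compound 3 to compound 4 (within the scatter), is the first measured one on a saturated chain carbon bound to an aromatic carbon, and the two numbers cannot be told apart. Diethylamino has 5 heavy atoms and no ring, whereas 4-(ethoxycarbonyl)piperazin-1-yl has 11 heavy atoms, one six-membered non-aromatic ring with 2 hetero atoms, and 3 hydrogen-bond acceptors, so this place accepts a much larger group with no read-out change beyond the scatter. The earlier step, on a saturated chain carbon bound to an oxygen on an aromatic ring, could not show this, since it concerned a different place.

Going by these compounds, whether a morpholine, an unsubstituted piperazine, a carboxylic acid or a longer chain carrying the amine at this place would leave the number within the scatter of these two compounds stays open, as does the effect of removing the ethoxycarbonyl group alone. No measurement is available that gives a reason for the number of either compound at this place.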